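Cytotoxicity notes: from compound 3 to compound 4

This account rests on a few compounds, and the source may have more. Where it says the series, first, only, none or still open, it means among the compounds named here.

Measured so far in an ADME assay on MT4 cells (Homo sapiens) for cytotoxicity, read by MTT assay; a higher number here means that more compound is tolerated, a lower number that less compound is tolerated:
- compound 1 `Cc1cc(C)cc(S(=O)(=O)c2c(C(=O)NCC(=O)NCCn3c(C)cnc3[N+](=O)[O-])[nH]c3ccc(Cl)cc23)c1`: 24500 nM
- compound 2 `Cc1cc(C)cc(S(=O)(=O)c2c(C(=O)NC(C)c3cc(F)cc(F)c3)[nH]c3ccc(Cl)cc23)c1`: a limit of the assay, > 49700 nM
- compound 3 `Cc1cc(C)cc(S(=O)(=O)c2c(C(=O)NC(C)C(=O)NCc3ccncn3)[nH]c3ccc(Cl)cc23)c1`: 28100 nM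
- compound 4 `Cc1cc(C)cc(S(=O)(=O)c2c(C(=O)NCC(=O)NCc3ccccc3F)[nH]c3ccc(Cl)cc23)c1`: not yet measured

Compound 3 carries one of two numbers in this assay; compound 1 sits within the scatter of it, so the two are not ordered. Compound 2 gives only a limit, (the limit of > 49700 nM in this assay, at which 1 of the 3 values shown sits). Going by the values given here, the single step with one change is an at least 1.7-fold lower number from compound 2 to compound 3 (0.24 log units; that floor lies within the scatter), and its floor lies within the scatter, so it shows no more than that the pyrimidinylmethylcarbamoyl compound tolerates somewhat less compound than the difluorophenyl one may.

The step to compound 4 is a group of 12 heavy atoms (9 carbon, 1 nitrogen, 1 oxygen, 1 fluorine; one six-membered aromatic ring of carbon only) in place of a group of 12 heavy atoms (8 carbon, 3 nitrogen, 1 oxygen; one six-membered aromatic ring with 2 hetero atoms), on an amide-type nitrogen. It exchanges a ring with two hetero atoms for a ring of carbon only, the reverse sense of the measured step, which supports a move toward the limit rather than away from it. Compound 4 is therefore expected to give a 1.2-fold higher number from compound 3 to compound 4 (0.10 log units; within the scatter), a step within the scatter. The estimate for compound 4 in this assay is 35000 nM, with a range from 17000 nM to 70000 nM, and a fair chance that only a limit is reported.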

Compound 4, half-maximal cytotoxic concentration: > 47300 nM
Compound 4: no number, only a limit (the forecaster's own chance of this, stated with the estimate: 35%); at least 1.3-fold (0.13 log units) between middle value and limit.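

In this assay compound 4 gives no number, only a limit of the assay: the limit of > 47300 nM in this assay, at which 1 of the 4 values shown sits.

On the amide-type nitrogen, ((2-fluorobenzyl)carbamoyl)methyl in place of the group of compound 3 gives an at least 1.6-fold higher number from compound 3 to compound 4 (0.22 log units; that floor lies within the scatter), and the group with a ring of carbon only, in place of the five-membered aromatic ring group of compound 1, gives an at least 1.9-fold higher number from compound 1 to compound 4 (0.28 log units; that floor lies within the scatter); both floors lie within the scatter, so the steps only point the same way and do not establish a real change. The new finding is that a compound with a carbamoyl chain at this position can also end at a limit, but the step between compound 2 and compound 4 cannot be read, and compound 2 likewise gives only a limit of the assay: the limit of > 49700 nM in this assay, at which 1 of the 4 values shown sits.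

The compounds shown leave open how much compound is tolerated beyond the limit for compound 4, and whether the ring of carbon only or its fluorine goes with the step. A carboxylic acid or a primary amine in place of that fluorine would test the second question, provided the result is a number rather than a limit.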